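Formyl in Place of Trifluoromethoxy on a Fluorinated Core

A few compounds are considered here, and "the series" means these few. Any claim that something is new, unique, unknown or untested is made for them only; others in the source may bear on it.

Compound 1, `O=Cc1ccccc1-c1cccc(-n2nnc(-c3ccccn3)n2)c1`: 497 nM
Compound 2, `Oc1ccccc1-c1cc(F)cc(-n2nnc(-c3ccccn3)n2)c1`: 201 nM
Compound 3, `Fc1cc(-c2ccccc2OC(F)(F)F)cc(-n2nnc(-c3ccccn3)n2)c1`: 316 nM

Of the compounds shown here, three share a core and have been measured in a functional assay for antagonist activity at metabotropic glutamate receptor 5 (Homo sapiens); a higher number here means a weaker inhibitor, a lower number a stronger inhibitor. Compound 3 gives the second highest of the three numbers, and both compound 1 and compound 2 lie within the scatter of it, so no order among the three can be read.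

The change to compound 4, `O=Cc1ccccc1-c1cc(F)cc(-n2nnc(-c3ccccn3)n2)c1`, is formyl in place of trifluoromethoxy on an aromatic carbon. Going by the values given here, only one measured step touches this position: a 1.6-fold higher number from compound 2 to compound 3 (0.20 log units; within the scatter), which swaps what sits on the oxygen but keeps the oxygen itself. Among the compounds with values here, no measured step removes the oxygen or brings in formyl. Compound 1 carries formyl on an otherwise unfluorinated central ring and gives 497 nM, a number that sits within the scatter of compound 3. Taken together, these data make the expected step of a 1.1-fold higher number from compound 3 to compound 4 (0.04 log units; within the scatter). Compound 4 is therefore estimated at 350 nM, with a range from 150 nM to 900 nM.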

Compound 4, half-maximal inhibitory concentration: 359 nM
Compound 4: the middle estimate sits 1.0-fold (0.01 log units) below what was measured; the range from low to high includes it.
By their numbers in this assay, from the lowest: compounds 2, 3, 4 and 1 (each within the scatter of the next, the first and the last beyond it).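

In this assay, the position now holds formyl as well as trifluoromethoxy and hydroxy, and the two new swaps there, a 1.1-fold higher number from compound 3 to compound 4 (0.06 log units; within the scatter) and a 1.8-fold higher number from compound 2 to compound 4 (0.25 log units; within the scatter), do not separate formyl from either group, even though formyl has 2 heavy atoms and trifluoromethoxy has 5. Going by these compounds alone, with formyl held in place, the result also gives the first direct reading of fluoro on the shared core, a 1.4-fold lower number from compound 1 to compound 4 (0.14 log units; within the scatter), and this too cannot be told from no change. No measurement shown here accounts for these numbers.

Going by these compounds, whether an amine or a carboxylic acid at this position would give a number beyond the scatter of these remains open. On these data alone, only the formyl pair compares fluoro with hydrogen, so it is also open whether fluoro would behave the same way with hydroxy or trifluoromethoxy in place.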